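Moving the two fluorines on the benzyl group

The source may hold more compounds than are shown below. What is called first, only, known or untested is meant among the compounds shown, and "the series" means these compounds.

Compound 3 `CC1(C)c2[nH]nc(NC(=O)c3ccccc3)c2CN1Cc1cc(F)cc(F)c1` gives the lowest number of the three measured compounds in an assay on Sf21 cells for inhibition of high affinity nerve growth factor receptor (Homo sapiens), read by HTRF, with a stated time of 30 min, in the presence of a further agent that is not named here (a higher number here means a weaker inhibitor, a lower number a stronger inhibitor), at 190 nM. Compound 1 `CC1(C)c2[nH]nc(NC(=O)c3ccccc3)c2CN1Cc1cccc(C#N)c1` gives 980 nM in this assay, and compound 2 `CC1(C)c2[nH]nc(NC(=O)c3ccccc3)c2CN1Cc1cccc(Br)c1` gives 940 nM. The step of a 1.0-fold lower number from compound 1 to compound 2 (0.02 log units; within the scatter) lies within the scatter, whereas a 5.2-fold lower number from compound 1 to compound 3 (0.71 log units; beyond the scatter) and a 4.9-fold lower number from compound 2 to compound 3 (0.69 log units; beyond the scatter) are both modest gains.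

Compound 4 `CC1(C)c2[nH]nc(NC(=O)c3ccccc3)c2CN1Cc1c(F)cccc1F` differs from compound 3 in one place: 2,6-difluorophenyl in place of 3,5-difluorophenyl on a saturated chain carbon bound to an amine nitrogen in a ring. Going by the values given here, no measured step exchanges one difluorophenyl for another, so no measured pair bears directly on this change. The steps to compound 3 only show that the choice of substituent on the benzyl ring can shift the number modestly; they say nothing about moving the fluorines themselves.

The result for compound 4 is therefore expected to lie near that of compound 3, with a wide range, a 2.1-fold higher number from compound 3 to compound 4 (0.32 log units; beyond the scatter). Compound 4 is estimated at 400 nM in this assay, between 120 nM and 1500 nM.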

Compound 4, half-maximal inhibitory concentration: 520 nM
Compound 4: middle estimate off by 1.3-fold (0.11 log units), on the low side; measured number inside the range.
By their numbers in this assay, from the lowest: compound 3; then compounds 4, 2 and 1 (each within the scatter of the next).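

In this assay, the two fluorines count for more than their mere presence: with the same atoms joined differently, the change reads a 2.7-fold higher number from compound 3 to compound 4 (0.44 log units; beyond the scatter) and so takes back part of the gain seen with compound 3. The other two comparisons, a 1.8-fold lower number from compound 2 to compound 4 (0.26 log units; within the scatter) and a 1.9-fold lower number from compound 1 to compound 4 (0.28 log units; within the scatter), leave compound 4 not distinguishable from compound 2 or compound 1, so the 2,6-difluorophenyl group shows no clear advantage over the 3-bromophenyl or 3-cyanophenyl groups. Nothing available here explains why moving the fluorines has this effect.

On these data alone, it remains open how a single fluorine on this benzyl ring would compare, and whether an amine or a carboxylic acid there would give a lower or a higher number. As far as these compounds go, it is also open whether the gap between the two difluorophenyl groups would persist if the rest of the molecule changed.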